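A few compounds are considered here, and "the series" means these few. Any claim that something is new, unique, unknown or untested is made for them only; others in the source may bear on it.

Two values stand in a functional assay on MCF7 cells (Homo sapiens) for antiproliferative activity, read by MTT assay, with a stated time of 72 h; on this read-out higher numbers stand for weaker inhibition and lower numbers for stronger inhibition. Compound 1 `O=c1[nH]c(=O)n(CCC(CO)CO)cc1-c1ccco1` reaches a limit of the assay, < 10 nM, and that is the limit of < 10 nM in this assay, at which 1 of the 2 values shown sits. Compound 2 `CC(=O)OCC(CCn1cc(C#CCc2ccccc2)c(=O)n(C(=O)c2ccccc2)c1=O)COC(C)=O` gives 26800 nM, the only full number shown, so compound 2 stands at the weak end of what has been measured. Compound 3 `CC(=O)OCC(CCn1cc(C#CCCCCl)c(=O)n(C(=O)c2ccccc2)c1=O)COC(C)=O` differs from compound 2 by 2-chloroethyl in place of phenyl on a saturated chain carbon bound to a triple-bonded carbon. For the measured compounds named here, no measured step bears on this exchange, so no move beyond the scatter is expected in either direction. Compound 3 is expected to give 27000 nM, within 9000 nM to 80000 nM. The expected step is a 1.0-fold higher number from compound 2 to compound 3 (0.00 log units; within the scatter).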

Compound 3, half-maximal inhibitory concentration: 21000 nM
For compound 3 the middle estimate is 1.3-fold (0.11 log units) above the measured one, and the stated range covers the measured number.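

At the saturated chain carbon bound to a triple-bonded carbon, 2-chloroethyl in place of phenyl gives a 1.3-fold lower number from compound 2 to compound 3 (0.11 log units; within the scatter) in this assay. Across this pair, the six-membered aromatic ring is therefore not required to keep the read-out in the same range. Nothing measured here bears on why this exchange leaves the read-out within the scatter.

On these data alone, whether an amine, a carboxylic acid or a longer chain at this place would shift the read-out remains open. Compound 1 differs from compound 2 and compound 3 in more than one place, so what separates it from them cannot be read.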